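Lengthening a Urea Chain on a Second Core

A few compounds are considered here, and "the series" means these few. Any claim that something is new, unique, unknown or untested is made for them only; others in the source may bear on it.

Of the compounds shown here, three have been measured in an assay for inhibition of Nitric oxide synthase, inducible (Homo sapiens), read by scintillation counting, with a stated time of 30 min, tested at 1 mM; on this read-out lower numbers stand for less inhibition and higher numbers for more inhibition at the one concentration tested (going by the name of the read-out). Compound 1 `CCNC(=O)NCCC(O)c1cc(OC)ccc1N` gives 26.6%. Compound 2 `CCCNC(=O)NCCC(O)c1cc(OC)ccc1N` differs from compound 1 by methyl in place of hydrogen on a saturated chain carbon, two bonds along the chain from an amide-type nitrogen. In this assay compound 2 gives 14.7%. The step of a number 11.9 percentage points lower from compound 1 to compound 2 (beyond the scatter) reaches beyond the usual scatter. Compound 3 `CCNC(=O)NCCC(O)c1cc(Cl)ccc1N` carries a different core and differs from compound 1 by chloro in place of methoxy on an aromatic carbon. In this assay compound 3 gives 33.9%. The step of a number 7.3 percentage points higher from compound 1 to compound 3 (within the scatter) stays within the scatter, so the two cores cannot be told apart from these two numbers.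

Compound 4 `CCCNC(=O)NCCC(O)c1cc(Cl)ccc1N` has not yet been measured. It differs from compound 3 by methyl in place of hydrogen on a saturated chain carbon, two bonds along the chain from an amide-type nitrogen. This is the same change that was made from compound 1 to compound 2, at the same place on the chain; seen one bond further out, it reads ethyl to propyl. Among the compounds with values here, that earlier step is the only measured guide, and it was made only once, so whether it carries over to the core of compound 3 remains open.

For compound 4 the number in this assay is expected to lie near 22%, between 8% and 36%, which would mean a step of a number 11.9 percentage points lower from compound 3 to compound 4 (beyond the scatter). This expectation rests on the step of a number 11.9 percentage points lower from compound 1 to compound 2 (beyond the scatter) being repeated on a core that itself sits within the scatter of compound 1, as the step of a number 7.3 percentage points higher from compound 1 to compound 3 (within the scatter) shows.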

Compound 4, a percentage reported as inhibition, at one concentration (the size of the read-out at that concentration, not a potency): 19.6%
Estimate against measurement, compound 4: 2.4 percentage points above; measured number inside the range.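

On the core of compound 3, going from ethyl to propyl in this assay gives a number 14.3 percentage points lower from compound 3 to compound 4 (beyond the scatter), so the drop seen on the core of compound 1 appears again on the second core, and by a matching amount: the same change on two cores in this assay, a number 11.9 percentage points lower (beyond the scatter) from compound 1 to compound 2 and a number 14.3 percentage points lower (beyond the scatter) from compound 3 to compound 4, 2.4 percentage points apart, within the scatter of two such steps. Read the other way, chloro in place of methoxy on the propyl compounds gives a number 4.9 percentage points higher from compound 2 to compound 4 (within the scatter), so the two cores still cannot be told apart, whichever chain they carry: the same change on two cores in this assay, a number 7.3 percentage points higher (within the scatter) from compound 1 to compound 3 and a number 4.9 percentage points higher (within the scatter) from compound 2 to compound 4, 2.4 percentage points apart, within the scatter of two such steps. This shows that the chain change carried over between these two cores, but it rests on just two pairs of compounds, each read at one concentration, so it does not show that the change would behave the same way on any other core, and it says nothing about why the longer chain goes with the lower number.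

The compounds shown leave open whether a longer chain such as butyl would lower the number further, or whether a shorter one such as methyl would raise it. They also leave open whether the same chain step would hold with another group, such as fluoro or a nitrile, in place of the chloro or methoxy.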